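The source may report more compounds than this note shows. Statements on the series, on what has been measured and on what is new or still open speak of the compounds shown alone.

In a functional assay on HepG2 cells (Homo sapiens) for cytotoxicity, read by MTT assay, with a stated time of 24 h (a higher number here means a weaker inhibitor, a lower number a stronger inhibitor), compound 1 (`CC(=O)Nc1ccc(S(=O)(=O)N2C/C(=C\c3cccc([N+](=O)[O-])c3)C(=O)/C(=C/c3cccc([N+](=O)[O-])c3)C2)cc1`) gives 7140 nM and compound 2 (`CC(=O)Nc1ccc(S(=O)(=O)N2C/C(=C\c3cccc([N+](=O)[O-])c3)C(=O)/C(=C/c3ccccc3F)C2)cc1`) gives 8800 nM while compound 3 (`COc1cc(/C=C2\CN(S(=O)(=O)c3ccc(NC(C)=O)cc3)C/C(=C\c3ccccc3F)C2=O)cc(OC)c1OC`) gives 4750 nM and so stands within the scatter of both. Compound 4 (`COc1cc(/C=C2\CN(S(=O)(=O)c3ccc(NC(C)=O)cc3)C/C(=C\c3cccc([N+](=O)[O-])c3)C2=O)cc(OC)c1OC`) carries 3-nitrophenyl in place of 2-fluorophenyl on a double-bonded chain carbon bound to a double-bonded ring carbon. The same exchange, read in reverse, appears as a 1.2-fold higher number from compound 1 to compound 2 (0.09 log units; within the scatter) and the entry of 3,4,5-trimethoxyphenyl in place of 3-nitrophenyl appears as a 1.9-fold lower number from compound 2 to compound 3 (0.27 log units; within the scatter) and both steps are small. No step beyond the scatter is therefore expected in this assay for this change. The expected size is a 1.1-fold lower number from compound 3 to compound 4 (0.05 log units; within the scatter) on this estimate. Compound 4 is estimated at 4200 nM with an expected range from 2200 nM to 8000 nM on present data.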

Compound 4, half-maximal inhibitory concentration: 3340 nM
Compound 4: the middle estimate sits 1.3-fold (0.10 log units) above what was measured, within the range that was stated.
By their numbers in this assay, from the lowest: compounds 4, 3, 1 and 2 (each within the scatter of the next, the first and the last beyond it).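

In this assay the exchange between 2-fluorophenyl and 3-nitrophenyl at this place now reads on a second core, with a 1.4-fold lower number from compound 3 to compound 4 (0.15 log units; within the scatter) and no step beyond the scatter on either core: the same change on two cores in this assay, a 1.2-fold higher number (0.09 log units; within the scatter) from compound 1 to compound 2 and a 1.4-fold higher number (0.15 log units; within the scatter) from compound 4 to compound 3, 1.2-fold (0.06 log units) apart, within the scatter of two such steps.
Among the compounds shown here, the entry of 3,4,5-trimethoxyphenyl now gives the first steps beyond the scatter, a 2.6-fold lower number from compound 2 to compound 4 (0.42 log units; beyond the scatter) and a 2.1-fold lower number from compound 1 to compound 4 (0.33 log units; beyond the scatter), both modest.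
That change also agrees across two cores: the same change on two cores in this assay, a 1.9-fold lower number (0.27 log units; within the scatter) from compound 2 to compound 3 and a 2.1-fold lower number (0.33 log units; beyond the scatter) from compound 1 to compound 4, 1.2-fold (0.06 log units) apart, within the scatter of two such steps.
These compounds leave open whether a simple phenyl, an amine or a carboxylic acid on the phenyl ring would shift the number at this place.
As far as these compounds go, a longer chain in place of the aryl group also remains open.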